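A few compounds are considered here, and "the series" means these few. Any claim that something is new, unique, unknown or untested is made for them only; others in the source may bear on it.

Measured so far:
compound 1 `Nc1nc(-c2ccco2)nc2sc(CN3CCC(F)(F)CC3)cc12` — 2230 nM
compound 2 `CCc1ccc(-c2nc(N)c3cc(CN4[C@H](C)CCC[C@@H]4C)sc3n2)o1` — 190 nM

In an assay on CHO-K1 cells for antagonist activity at adenosine receptor A1 (Homo sapiens), read by a beta-galactosidase reporter, with stated times of 15 min and 6 h (on this read-out lower numbers stand for stronger inhibition and higher numbers for weaker inhibition), compound 2 gives 190 nM, the lower of the two numbers; compound 1 gives 2230 nM, a gap beyond the scatter. Compound 3 `C[C@@H]1CCC[C@H](C)N1Cc1cc2c(N)nc(-c3ccc(C(F)F)o3)nc2s1` keeps the core of compound 2 and differs only by difluoromethyl in place of ethyl on an aromatic carbon. Within the data shown here, nothing among the measured pairs shows what this exchange does. The step from compound 2 to compound 3 is expected to be small, a 1.4-fold higher number from compound 2 to compound 3 (0.14 log units; within the scatter), and not clearly beyond the scatter, if anything toward a weaker number. Compound 3 is therefore estimated at 260 nM, within 80 nM to 850 nM.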

Compound 3, inhibition constant: 730 nM
Compound 3: middle estimate off by 2.8-fold (0.45 log units), on the low side, within the range that was stated.
By their numbers in this assay, from the lowest: compound 2; then compound 3; then compound 1.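

In this assay the exchange of ethyl for difluoromethyl on the five-membered aromatic ring with 1 oxygen gives a 3.8-fold higher number from compound 2 to compound 3 (0.58 log units; beyond the scatter) and so is not a neutral swap. This position therefore responds to the group it carries, and here the change goes toward weaker inhibition. Nothing available explains this step. The compounds shown leave open how methyl, a longer chain such as propyl, or an amine would read at this place. They also leave open whether the same exchange gives a similar step with a different amine on the shared core.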